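Hydroxy for Ethyl on the Alkynyl Chain of Compound 1

The compounds below may be only part of what the source reports. "The series", "measured", "known", "first", "only" and "open" are said of these compounds alone.

Measured compounds:
- compound 1, `CCCCC#Cc1cn([C@H]2C[C@H](O)[C@@H](CO)O2)c(=O)[nH]c1=O`: 1000 ug/mL
- compound 2, `C#Cc1cn(C2O[C@H](CO)[C@@H](O)[C@@H]2O)c(=O)[nH]c1=O`: 45 ug/mL

In a functional assay on L1210 cells (Mus musculus) (a lower number here means a stronger inhibitor, a higher number a weaker inhibitor), compound 1 gives 1000 ug/mL, the highest of the two numbers, so it is the weaker inhibitor. Compound 2 gives 45 ug/mL, a lower number, beyond the scatter.

Compound 3, `O=c1[nH]c(=O)n([C@H]2C[C@H](O)[C@@H](CO)O2)cc1C#CCCO`, has not been measured. It differs from compound 1 by hydroxy in place of ethyl on a saturated chain carbon, two bonds along the chain from a triple-bonded carbon. Among the compounds with values here, no pair of measured compounds shows this change, so its effect is uncertain. A moderate step toward a lower number is expected, a 3.3-fold lower number from compound 1 to compound 3 (0.52 log units; beyond the scatter), and compound 3 is estimated at 300 ug/mL, within 60 ug/mL to 1000 ug/mL.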

Compound 3, concentration for 50% inhibition: > 1000 ug/mL
Compound 3 gave a limit, no number; the forecaster's own chance of this, stated with the estimate: 20%; at least 3.3-fold (0.52 log units) between middle value and limit.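

In this assay, hydroxy in place of ethyl on a saturated chain carbon, two bonds along the chain from a triple-bonded carbon, gives a number no lower from compound 1 to compound 3 (the limit leaves the size open), the first direct view of a change at this position. Compound 3 stands at > 1000 ug/mL, which is a limit and not a number. This change therefore brings no gain in inhibition, and how much is lost, if anything, cannot be read: the limit of > 1000 ug/mL in this assay, at which 1 of the 3 values shown sits.

From the compounds shown here alone, whether an amine or a carboxylic acid at this place would give a lower number remains open. So does the effect of a longer chain.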